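Replacing Isopropyl with 4-Hydroxybutyl on the Shared Core

This account rests on a few compounds, and the source may have more. Where it says the series, first, only, none or still open, it means among the compounds named here.

Compound 1, `Nc1ncc(-c2cccc(Cl)c2)c(-c2ccccc2)n1`, in an assay on CHO cells for displacement of a labelled ligand from adenosine receptor A1 (Homo sapiens), read by scintillation counting, with a stated time of 1 h, tested at 1 uM (a lower number here means less inhibition, a higher number more inhibition at the concentration tested (going by the name of the read-out)), gives > 80%, which is a limit of the assay rather than a number.
Compound 2, `CCCC(=O)Nc1ncc(-c2cccc(Cl)c2)c(-c2ccccc2)n1`, in this assay gives > 80%, again a limit.
Compound 3, `CC(C)Nc1ncc(-c2cccc(Cl)c2)c(-c2ccccc2)n1`, in this assay gives 71%.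

Within the data shown here, compound 3 thus carries the only plain number among the three; the other two values sit at a limit, as the limit of > 80% in this assay, at which 2 of the 3 values shown sit, records. The two steps that lead to compound 3 read a number at least 9 percentage points lower from compound 1 to compound 3 (that floor lies within the scatter) and a number at least 9 percentage points lower from compound 2 to compound 3 (that floor lies within the scatter), each with a floor that lies within the usual scatter, so neither shows a clear loss. The step that the two limits leave unreadable from compound 1 to compound 2 cannot be read at all.

Compound 4, `OCCCCNc1ncc(-c2cccc(Cl)c2)c(-c2ccccc2)n1`, is the next one to be measured. The change is 4-hydroxybutyl in place of isopropyl on a nitrogen on an aromatic ring. Among the measured compounds shown here, no measured step swaps one alkyl group on that nitrogen for another, so the expectation leans on compound 3 itself: the hydrogen and the propylcarbonyl both sit at the limit, and the isopropyl gives a number close to it. The step from compound 3 to compound 4 is therefore expected to be small, a number 2 percentage points higher from compound 3 to compound 4 (within the scatter), in either direction within the scatter. Compound 4 is estimated to give 73% in this assay, in a range from 55% to 85%.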

Compound 4, a percentage reported as inhibition, at one concentration (the size of the read-out at that concentration, not a potency): > 80%
Compound 4: a limit, no number; the forecaster's own chance of this, stated with the estimate: 25%; at least 7 percentage points between middle value and limit.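

In this assay compound 4 gives > 80%, which is a limit of the assay and not a number. Its step, a number at least 9 percentage points higher from compound 3 to compound 4 (that floor lies within the scatter), means that exchanging isopropyl for 4-hydroxybutyl on a nitrogen on an aromatic ring shows no clear gain, but it does show that this position can carry a bigger group ending in a hydroxyl and still reach the limit, something that the hydrogen of compound 1 and the propylcarbonyl of compound 2 could not show. The steps from compound 1 to compound 4 and from compound 2 to compound 4 cannot be read, so these three compounds cannot be put in order, and the change cannot be sized: the limit of > 80% in this assay, at which 3 of the 4 values shown sit.

The compounds shown leave open whether the hydroxyl contributes anything, since a plain butyl chain on the same nitrogen would be needed to separate the oxygen from the length of the chain. They also leave open how far this position stretches, for instance to a longer chain, or to a chain ending in an amine or a carboxylic acid.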